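Benzylthioether variant of an inactive hydroxypropyl analogue

A few compounds are considered here, and "the series" means these few. Any claim that something is new, unique, unknown or untested is made for them only; others in the source may bear on it.

Measured compounds:
compound 1 `CC(C(=O)NCc1ccc(C(F)(F)F)nc1SCCCO)c1ccc(NS(C)(=O)=O)c(F)c1` — "not active" (no number reported)
compound 2 `CC(C(=O)NCc1ccc(C(F)(F)F)nc1SCCC(=O)O)c1ccc(NS(C)(=O)=O)c(F)c1` — "not active" (no number reported)
compound 3 `COC(=O)CCSc1nc(C(F)(F)F)ccc1CNC(=O)C(C)c1ccc(NS(C)(=O)=O)c(F)c1` — 48.2 nM

In an assay on CHO-K1 cells for antagonist activity at transient receptor potential cation channel subfamily V member 1 (Homo sapiens), read by FLIPR (on this read-out higher numbers stand for weaker inhibition and lower numbers for stronger inhibition), compound 1 is recorded as "not active" (no number reported), with no number given. Compound 2 likewise comes out as "not active" (no number reported) in this assay, again without a number. Only compound 3 carries a measured value, giving 48.2 nM in this assay. Compound 1 therefore stands among the two entries of the set without a number, and nothing places it on the scale relative to compound 3.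

Compound 4 `CC(C(=O)NCc1ccc(C(F)(F)F)nc1SCc1ccc(Cl)cc1)c1ccc(NS(C)(=O)=O)c(F)c1` differs from compound 1 by a single change: 4-chlorophenyl in place of 2-hydroxyethyl on a saturated chain carbon bound to a sulfur. For the measured compounds named here, no step between measured compounds exists that would show how this assay responds to such a change, and the two entries without numbers give no direction. Going by the values given here, the only anchor is that compound 3, whose thioether chain also ends in a group other than a hydroxyl, is measured at 48.2 nM in this assay, so a numbered result for compound 4 is plausible. A step from compound 1 toward stronger inhibition is expected, of a size that cannot be drawn from the data shown.

For compound 4 in this assay an inhibition constant of about 30 nM is estimated, expected to lie between 5 nM and 250 nM.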

Compound 4, inhibition constant: 8.7 nM
For compound 4 the middle estimate is 3.4-fold (0.54 log units) above the measured one; the measured number falls inside the stated range.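

In this assay the position on the sulfur accepts an aromatic end: compound 4, with (4-chlorobenzyl)sulfanyl, gives a measured number, whereas compound 1, with (3-hydroxypropyl)sulfanyl, gives "not active" (no number reported), so the size of that change cannot be read as a step. Against the only other numbered compound, 4-chlorophenyl in place of (methoxycarbonyl)methyl on a saturated chain carbon bound to a sulfur gives a 5.5-fold lower number from compound 3 to compound 4 (0.74 log units; beyond the scatter), which shows that an entering group with 0 hydrogen-bond donors and 0 hydrogen-bond acceptors can support stronger inhibition here than the ester-ended chain. No measurement available here explains this difference.

Going by these compounds, whether the aromatic ring alone or the chlorine on it accounts for the result stays open, as does how a plain benzyl or a longer chain such as 2-phenylethyl would read in this assay. An amine at the end of the chain also remains unplaced, with only compound 3 and compound 4 carrying numbers in this set.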